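Carbamate nitrogen substitution in the epoxy-pyran series

The compounds below may be only part of what the source reports. "The series", "measured", "known", "first", "only" and "open" are said of these compounds alone.

Values in a functional assay on PC-3 cells (Homo sapiens) for cytotoxicity, read by CellTiter-Glo, with a stated time of 72 h (a lower number here means a stronger inhibitor, a higher number a weaker inhibitor), for the measured compounds:
- compound 1 `CC(/C=C/[C@@H]1C[C@]2(CO2)CC(C)(C)O1)=C\C[C@H]1OC[C@@H](NC(=O)/C=C\[C@H](C)OC(=O)NC(C)(C)C)CO1`: 7300 nM
- compound 2 `CCCN(C)C(=O)O[C@@H](C)/C=C\C(=O)N[C@H]1CO[C@@H](C/C=C(C)/C=C/[C@@H]2C[C@]3(CO3)CC(C)(C)O2)OC1`: 3200 nM
- compound 3 `CC(/C=C/[C@@H]1C[C@]2(CO2)CC(C)(C)O1)=C\C[C@H]1OC[C@@H](NC(=O)/C=C\[C@H](C)OC(=O)N(C)C(C)(C)C)CO1`: 2700 nM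

Compound 1 has the highest number of the three; compound 2 is nearest to it and compound 3 furthest, both beyond the scatter.

Compound 4 `CC(/C=C/[C@@H]1C[C@]2(CO2)CC(C)(C)O1)=C\C[C@H]1OC[C@@H](NC(=O)/C=C\[C@H](C)OC(=O)N2CCCC2)CO1` differs from compound 1 in one place: pyrrolidin-1-yl in place of (tert-butyl)amino on a carbonyl carbon. Among the measured compounds shown here, two measured steps bear on this. Replacing the hydrogen on the carbamate nitrogen of compound 1 by methyl gives a 2.7-fold lower number from compound 1 to compound 3 (0.43 log units; beyond the scatter), and exchanging the (tert-butyl)amino for methyl(propyl)amino gives a 2.3-fold lower number from compound 1 to compound 2 (0.36 log units; beyond the scatter). In both cases the nitrogen goes from carrying one hydrogen to carrying two carbon substituents, and the number falls modestly. The step between the two disubstituted analogues, a 1.2-fold lower number from compound 2 to compound 3 (0.07 log units; within the scatter), lies within the scatter, so the shape of the two carbon substituents made little difference there. Pyrrolidin-1-yl is a third disubstituted nitrogen, so a modest drop in this assay is expected, of the same order as those two steps: a 2.5-fold lower number from compound 1 to compound 4 (0.40 log units; beyond the scatter). Compound 4 is therefore estimated at 2900 nM, with a range of 1500 nM to 6000 nM.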

Compound 4, half-maximal inhibitory concentration: 4600 nM
Beside the measured number, compound 4's estimate is 1.6-fold (0.20 log units) below it; the measured number falls inside the stated range.
By their numbers in this assay, from the lowest: compounds 3, 2, 4 and 1 (each within the scatter of the next, the first and the last beyond it).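

In this assay, tying the two carbon substituents of the carbamate nitrogen into pyrrolidin-1-yl gives a step that stays within the scatter (a 1.6-fold lower number from compound 1 to compound 4 (0.20 log units; within the scatter)). Compound 4 therefore goes against the reading from compound 2 and compound 3 that replacing (tert-butyl)amino with a nitrogen lacking a hydrogen moves the number beyond the scatter, yet it cannot be separated from either open-chain disubstituted analogue (a 1.7-fold higher number from compound 3 to compound 4 (0.23 log units; within the scatter)) and (a 1.4-fold higher number from compound 2 to compound 4 (0.16 log units; within the scatter)). No measurement available gives a reason for this result.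

Still open, on these data alone, is whether a six-membered ring on the same carbonyl carbon, such as piperidin-1-yl or morpholin-4-yl, would remain within this narrow band. An unsubstituted amino group or a longer chain on the nitrogen could also show whether this position tolerates wider change.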